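The source may report more compounds than this note shows. Statements on the series, on what has been measured and on what is new or still open speak of the compounds shown alone.

Compound 1 `CNC(=O)c1cc(Oc2ccc(NC(=O)c3nn(-c4ccccc4C(F)(F)F)c(=O)cc3C)cc2F)ccn1` gives 35700 nM in a functional assay on MCF7 cells (Homo sapiens) for cytotoxicity, read by MTT assay, with a stated time of 72 h; a higher number here means a weaker inhibitor, a lower number a stronger inhibitor. Compound 2 `Cc1cc(=O)n(-c2ccccc2C(F)(F)F)nc1C(=O)Nc1ccc(Oc2ncnc3ccsc23)cc1` gives 5550 nM in this assay.

Compound 2 holds the lower of the two numbers; compound 1 stands well apart from it, beyond the usual scatter. Compound 3 `Cc1cc(=O)n(-c2ccccc2C(F)(F)F)nc1C(=O)Nc1ccc(Oc2ncnc3ccsc23)c(F)c1` differs from compound 2 by fluoro in place of hydrogen on an aromatic carbon. Going by the values given here, no pair of measured compounds shows a change of this kind, so no measured step guides the expectation. The expected step from compound 2 to compound 3 is a 1.1-fold lower number from compound 2 to compound 3 (0.05 log units; within the scatter), which is not beyond the scatter. Compound 3 is therefore estimated at 5000 nM, with a range from 1500 nM to 16000 nM in this assay.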

Compound 3, half-maximal inhibitory concentration: 6020 nM
The estimate for compound 3 lay 1.2-fold (0.08 log units) below the measured number; measured number inside the range.
By their numbers in this assay, from the lowest: compounds 2 and 3 (each within the scatter of the next); then compound 1.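

In this assay, fluoro in place of hydrogen on this aromatic carbon gives a 1.1-fold higher number from compound 2 to compound 3 (0.04 log units; within the scatter), so this single change leaves the number within the scatter. The group on the oxygen matters more here: the group with a five-membered aromatic ring, in place of the group with a six-membered aromatic ring bearing one hetero atom, gives a 5.9-fold lower number from compound 1 to compound 3 (0.77 log units; beyond the scatter). Nothing at hand accounts for either step. The compounds shown leave open whether chloro, methoxy or an amine on this same carbon would also stay within the scatter.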